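From 4-cyanobenzyl to 2-cyanobenzyl: compound 3 to compound 4

The compounds below may be only part of what the source reports. "The series", "measured", "known", "first", "only" and "open" are said of these compounds alone.

Values in a functional assay on HUVEC cells (Homo sapiens) for antiproliferative activity, read by MTT assay, with a stated time of 24 h (a higher number here means a weaker inhibitor, a lower number a stronger inhibitor), are these:
- compound 1 `COc1cc(OC)c(-c2coc3cc(OCc4ccc(Br)cc4)ccc3c2=O)cc1OC` gives > 10000 nM (a limit)
- compound 2 `COc1cc(OC)c(-c2coc3cc(OCc4ccccc4C)ccc3c2=O)cc1OC` gives 4830 nM
- compound 3 `COc1cc(OC)c(-c2coc3cc(OCc4ccc(C#N)cc4)ccc3c2=O)cc1OC` gives > 10000 nM (a limit)

Compound 3 has no number, only the limit of > 10000 nM in this assay, at which 2 of the 3 values shown sit, as its reading. Going by the values given here, compound 4 `COc1cc(OC)c(-c2coc3cc(OCc4ccccc4C#N)ccc3c2=O)cc1OC` carries 2-cyanophenyl in place of 4-cyanophenyl on a saturated chain carbon bound to an oxygen on an aromatic ring as its one change. Among the compounds with values here, two steps bear on this: an at least 2.0-fold lower number from compound 1 to compound 2 (0.31 log units; beyond the scatter) and an at least 2.0-fold higher number from compound 2 to compound 3 (0.31 log units; beyond the scatter) in the opposite sense. Both are at least modest and both involve the 2-methylphenyl member. Also shown is a step that the two limits leave unreadable from compound 1 to compound 3 with no size to use. Within the data shown here, the expectation rests on compound 2 with 4830 nM as the only number. For compound 4 a further limit remains possible. In this assay a modest move to a lower number is expected, the estimated step being an at least 1.4-fold lower number from compound 3 to compound 4 (0.15 log units; that floor lies within the scatter) overall. Compound 4 is estimated at 7000 nM with an expected range from 3000 nM to 14000 nM for now.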

Compound 4, half-maximal inhibitory concentration: > 10000 nM
Compound 4 was reported as a limit (the forecaster's own chance of this, stated with the estimate: 45%); middle value at least 1.4-fold (0.15 log units) from the limit.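

In this assay compound 4 gives > 10000 nM, a limit. Cyano in place of methyl on an aromatic carbon gives an at least 2.0-fold higher number from compound 2 to compound 4 (0.31 log units; beyond the scatter), so the measurable reading of the 2-methylphenyl member does not carry over to 2-cyanophenyl. The steps to compound 4 from compound 1 and from compound 3 cannot be read, as both ends of each are limits.

Going by these compounds, whether 2-cyanophenyl and 4-cyanophenyl differ at all stays open, with the series mostly unresolved at: the limit of > 10000 nM in this assay, at which 3 of the 4 values shown sit. Also open, on these data alone, is whether an amine or a carboxylic acid in place of the nitrile would give a number.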